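Compound 3: a 3-bromophenyl swap at a limit

A few compounds are considered here, and "the series" means these few. Any claim that something is new, unique, unknown or untested is made for them only; others in the source may bear on it.

In a functional assay on A549 cells (Homo sapiens) for cytotoxicity, read by MTT assay, with a stated time of 72 h (a higher number here means a weaker inhibitor, a lower number a stronger inhibitor), compound 1 `O=C(N/N=C/c1ccc(C(F)(F)F)cc1)N1CCc2ncnc(Nc3ccc(F)c(Cl)c3)c2C1` gives 37800 nM. Compound 2 `O=C(N/N=C/c1cccs1)N1CCc2ncnc(Nc3ccc(F)c(Cl)c3)c2C1` gives > 200000 nM, which is a limit and not a number. Compound 3 `O=C(N/N=C/c1cccs1)N1CCc2ncnc(Nc3cccc(Br)c3)c2C1` carries 3-bromophenyl in place of 3-chloro-4-fluorophenyl on a nitrogen on an aromatic ring. Within the data shown here, the only measured step, an at least 5.2-fold higher number from compound 1 to compound 2 (0.72 log units; beyond the scatter), is beyond the scatter but concerns a group on a carbon with a double bond to nitrogen, so no measured step covers this change. The expected change, an at least 1.3-fold lower number from compound 2 to compound 3 (0.12 log units; that floor lies within the scatter), is small and towards a lower number, if any. Compound 3 is estimated at 150000 nM, with an expected range of 50000 nM to 300000 nM.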

Compound 3, half-maximal inhibitory concentration: 50300 nM
For compound 3 the middle estimate is 3.0-fold (0.47 log units) above the measured one, within the range that was stated.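

Among these compounds, replacing 3-chloro-4-fluorophenyl with 3-bromophenyl on a nitrogen on an aromatic ring gives an at least 3.9-fold lower number from compound 2 to compound 3 (0.59 log units; beyond the scatter) in this assay, so the result at this position depends on the group it carries, which the earlier compounds, differing only on a carbon with a double bond to nitrogen, did not show. The size of this step is only a floor, because compound 2 stands at a limit and not at a number: the limit of > 200000 nM in this assay, at which 1 of the 3 values shown sits.

The compounds shown leave open whether the bromine or the absence of the chlorine and fluorine accounts for the step, and whether the swap would act alike with 4-(trifluoromethyl)phenyl in place of thiophen-2-yl. As far as these compounds go, how an amine or a carboxylic acid on this phenyl ring would read in this assay also remains open.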